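Moving a Chloro Group onto a Fused Purine Core

The source may hold more compounds than are shown below. What is called first, only, known or untested is meant among the compounds shown, and "the series" means these compounds.

This short series studies how small changes to a chlorinated fused-ring core, carrying a benzyl arm with a chloromethyl group, affect the killing of colon cancer cells in a functional assay on HT-29 cells (Homo sapiens) for cytotoxicity, read by sulforhodamine B assay, with a stated time of 48 h; on this read-out higher numbers stand for lower toxicity in this test and lower numbers for higher toxicity in this test. Compound 1 `ClCc1ccc(Cn2cnc3c(Cl)ncnc32)cc1` and compound 2 `ClCc1ccccc1Cn1cnc2c(Cl)ncnc21` differ only in where the chloromethyl group sits on the benzyl arm, while compound 3 `ClCc1ccc(Cn2cnc3ncnc(Cl)c32)cc1` attaches the same arm to a different ring nitrogen of the core. For compound 1 the result in this assay is "not determined" (no result reported). Compound 2 reaches only a limit in this assay, namely > 100000 nM, so no exact number is known for it. Among the measured compounds shown here, compound 3 gives 56200 nM in this assay, which is the only real number in the set. One further entry is a limit, as noted in the limit of > 100000 nM in this assay, at which 1 of the 3 values shown sits, and one has no result.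

Compound 4 `ClCc1ccc(Cn2cnc3nc(Cl)nc(Cl)c32)cc1` is built from compound 3 by a single change: chloro in place of hydrogen on an aromatic carbon. For the measured compounds named here, no pair of measured compounds shows what such a change does here, so the expected step is uncertain. The step of a 1.4-fold lower number from compound 3 to compound 4 (0.15 log units; within the scatter) is expected to be small, close to the usual scatter, with at most a slight lean toward stronger cell killing. Compound 4 is therefore estimated at 40000 nM, with a likely range from 10000 nM to 150000 nM.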

Compound 4, concentration lethal to 50% of the cells: > 100000 nM
Compound 4: only a limit was reported; the forecaster's own chance of this, stated with the estimate: 25%; middle value at least 2.5-fold (0.39 log units) away from the limit.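

In this assay chloro in place of hydrogen on the aromatic carbon between two ring nitrogen atoms gives an at least 1.7-fold higher number from compound 3 to compound 4 (0.25 log units; that floor lies within the scatter) and so no sign of stronger cell killing at this position. Going by these compounds, the result for compound 4 is a limit, so the true size of the step stays unknown. Among the compounds shown here, compound 3 thus keeps the only exact number, while compound 2 and compound 4 share one limit: the limit of > 100000 nM in this assay, at which 2 of the 4 values shown sit.

On these data alone, it remains open whether a different group on this carbon, such as an amine or a methoxy group, would shift the cell killing in either direction. Also open, as far as these compounds go, is whether the same chloro change would act alike on the core of compound 1, where the arm sits on a different ring nitrogen.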